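The source may report more compounds than this note shows. Statements on the series, on what has been measured and on what is new or still open speak of the compounds shown alone.

Compound 1 `Nc1nc(NC2CC2)c2ncn(/C=C3/CC3(CO)CO)c2n1` is the starting point. Among the compounds with values here, in an ADME assay on BCBL1 cells (Homo sapiens) for cytotoxicity, with a stated time of 7 days (a lower number here means that less compound is tolerated, a higher number that more compound is tolerated), compound 1 gives 71500 nM, and among the three values shown it is the only one that is a number rather than a limit. Compound 2 `CC(C)CNc1nc(N)nc2c1ncn2/C=C1/CC1(CO)CO` carries an isobutyl in place of the cyclopropyl on a nitrogen on the aromatic ring. In this assay compound 2 gives > 20000 nM, which is a limit of the assay and not a number. Compound 3 `CCCCCOc1nc(N)nc2c1ncn2/C=C1/CC1(CO)CO` carries a pentyloxy in place of the cyclopropylamino on an aromatic carbon. In this assay compound 3 gives > 20000 nM, again a limit of the assay. The steps a step that the limit leaves unreadable from compound 1 to compound 2, a step that the limit leaves unreadable from compound 1 to compound 3 and a step that the two limits leave unreadable from compound 2 to compound 3 therefore cannot be sized, since (the limit of > 20000 nM in this assay, at which 2 of the 3 values shown sit).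

Compound 4 `CCCCOc1nc(N)nc2c1ncn2/C=C1/CC1(CO)CO` is not yet measured. It differs from compound 1 as follows: butoxy in place of cyclopropylamino on an aromatic carbon. Within the data shown here, the closest measured step is the one to compound 3, a pentyloxy one carbon longer than the butoxy, and it reads only as a limit, so no direction can be taken from it beyond the observation that both measured neighbours tolerate at least as much compound as the limit.

The expectation for compound 4 is a step of a 1.2-fold lower number from compound 1 to compound 4 (0.08 log units; within the scatter), that is, essentially no change beyond the scatter. Compound 4 is estimated at 60000 nM, with a range from 20000 nM to 200000 nM.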

Compound 4, half-maximal cytotoxic concentration: > 20000 nM
Compound 4: no number, only a limit; the forecaster's own chance of this, stated with the estimate: 50%; the middle value is on the limit's open side.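

Compound 4 gives only a limit of the assay in this assay, so its steps from compound 1, compound 2 and compound 3 cannot be read: the limit of > 20000 nM in this assay, at which 3 of the 4 values shown sit.

The compounds shown leave open whether the butoxy, pentyloxy and isobutylamino groups of compound 4, compound 3 and compound 2 differ from one another, or from the cyclopropylamino group of compound 1, in this assay.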